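The source may report more compounds than this note shows. Statements on the series, on what has been measured and on what is new or still open speak of the compounds shown alone.

Notes on the urea series. Compound 1 `CCCc1ccc(NC(=O)N[C@@H](C)c2ccccc2)cc1` gives 76% in an ADME assay on the whole organism with Oryza sativa as the target, tested at 1 uM; a lower number here means a stronger effect, a higher number a weaker effect of the compound at the concentration tested. Going by the values given here, compound 2 `C[C@H](NC(=O)Nc1ccc(F)cc1)c1ccccc1` gives 97%, and the step of a number 21 percentage points higher from compound 1 to compound 2 (beyond the scatter) is the only one measured between neighbours that differ in one place. Compound 3 `C[C@@H](NC(=O)Nc1ccc(I)cc1)c1ccccc1` gives 91%, second highest of the three numbers, nearest to compound 2 and separated from compound 1 by a gap beyond the scatter.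

Compound 4 `C[C@H](NC(=O)Nc1ccc(I)cc1)c1ccccc1` is the next entry. How it differs from compound 3: the two compounds have the same atoms and bonds and differ only in configuration as drawn: 1 of 1 stereo elements differ; a stereocentre at a saturated chain carbon is drawn R in compound 3 and S in compound 4. Among the compounds with values here, no measured step in this set touches configuration alone; the only step known concerns a substituent swap on the aromatic ring. There is therefore no basis for expecting a step beyond the scatter, and the estimated step of a number 1 percentage points lower from compound 3 to compound 4 (within the scatter) is taken as essentially flat. Compound 4 is expected to give about 90% in this assay, within a range from 75% to 100%.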

Compound 4, a percentage reported as activity, at one concentration (the size of the read-out at that concentration, not a potency): 97%
For compound 4 the middle estimate is 7 percentage points below the measured one; the range from low to high includes it.
By their numbers in this assay, from the lowest: compound 1; then compounds 3, 2 and 4 (each within the scatter of the next).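

In this assay the drawn configuration at the saturated chain carbon gives a number 6 percentage points higher from compound 3 to compound 4 (within the scatter) and so no step beyond the scatter in this one pair: the fact that compounds 3 and 4 differ only in the configuration as drawn. With configuration held, iodo in place of fluoro gives no change at the digits printed from compound 2 to compound 4 (within the scatter) while iodo in place of propyl gives a number 21 percentage points higher from compound 1 to compound 4 (beyond the scatter) and so matches the earlier step in size. Among these compounds, only the pairs involving the propyl compound show a step beyond the scatter.

Going by these compounds, whether configuration is equally flat with propyl on the ring remains open. So does the effect of a carboxylic acid, an amine or a longer chain at that ring position.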